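Compound 3 to a chloro acid

This account rests on a few compounds, and the source may have more. Where it says the series, first, only, none or still open, it means among the compounds named here.

In a functional assay on K562 cells (Homo sapiens) for cytotoxicity, read by trypan blue exclusion, with a stated time of 96 h (on this read-out higher numbers stand for weaker inhibition and lower numbers for stronger inhibition), compound 1 `COc1cc(OC)c(/C=C/S(=O)(=O)Cc2ccc(OC)c([N+](=O)[O-])c2)c(OC)c1` gives 2500 nM, compound 2 `COC(=O)C(Nc1cc(CS(=O)(=O)/C=C/c2c(OC)cc(OC)cc2OC)ccc1OC)c1ccccc1` gives 30 nM and compound 3 `COC(=O)C(Nc1cc(CS(=O)(=O)/C=C/c2c(OC)cc(OC)cc2OC)ccc1OC)c1ccc(Br)cc1` gives 200 nM. Compound 3 therefore holds the second highest of the three numbers. Compound 4 `COc1cc(OC)c(/C=C/S(=O)(=O)Cc2ccc(OC)c(NC(C(=O)O)c3ccc(Cl)cc3)c2)c(OC)c1` has carboxy(4-chlorophenyl)methyl in place of (4-bromophenyl)(methoxycarbonyl)methyl on a nitrogen on an aromatic ring.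

Two measured steps are available. The more relevant is a 6.7-fold higher number from compound 2 to compound 3 (0.82 log units; beyond the scatter), a modest step with bromo in place of hydrogen on an aromatic carbon. Compound 4 still carries a halogen, so that step gives no reason to expect a return towards compound 2. The large step of an 83-fold lower number from compound 1 to compound 2 (1.92 log units; beyond the scatter) introduced the group now being altered, but gives no size for altering it. Within the data shown here, no measured compound carries the carboxy group, so that part of the change is untested. In this assay, no step beyond the scatter is expected, and no direction is firmly supported. The expected step is a 1.3-fold higher number from compound 3 to compound 4 (0.10 log units; within the scatter). Compound 4 is estimated at 250 nM, with an expected range of 50 nM to 1200 nM.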

Compound 4, half-maximal inhibitory concentration: 250 nM
The estimate for compound 4 equals the measured number at the digits printed; low and high end bracket the measured number.
By their numbers in this assay, from the lowest: compound 2; then compounds 3 and 4 (each within the scatter of the next); then compound 1.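

In this assay the exchange of (4-bromophenyl)(methoxycarbonyl)methyl for carboxy(4-chlorophenyl)methyl on the nitrogen gives a 1.3-fold higher number from compound 3 to compound 4 (0.10 log units; within the scatter) and so shows that this position tolerates a free carboxy group when it comes together with chloro in place of bromo. The acid stays apart from the halogen-free ester, with an 8.3-fold higher number from compound 2 to compound 4 (0.92 log units; beyond the scatter) as the step, and it keeps much of the gain over the nitro group, with a 10-fold lower number from compound 1 to compound 4 (1.00 log units; beyond the scatter) as the step. Nothing measured here accounts for these steps.

A bromo acid and a chloro ester would split the exchange into its two parts, which here cannot be told apart. Going by these compounds, it remains open whether a primary carboxamide or a tetrazole in place of the carboxy group would hold the same level.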